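Replacing Phenyl with Bromo in Compound 1

The source may hold more compounds than are shown below. What is called first, only, known or untested is meant among the compounds shown, and "the series" means these compounds.

In an ADME assay on THP-1 cells (Homo sapiens) for cytotoxicity, read by resazurin assay, with a stated time of 72 h (a higher number here means that more compound is tolerated, a lower number that less compound is tolerated), compound 1 (`O=C(/C=C/c1ccc([N+](=O)[O-])o1)c1ccc(-c2ccccc2)cc1`) gives 50400 nM. This is the higher of the two exact numbers available for the series. The other belongs to compound 3 (`Cc1ccc(C(=O)/C=C/c2ccc([N+](=O)[O-])s2)cc1`), which gives 13500 nM, a lower number by a margin beyond the usual scatter. For compound 2 (`CN(C)c1ccc(/C=C/C(=O)c2ccc(-c3ccccc3)cc2)cc1`), the reading of > 50000 nM is a limit and not an exact number.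

Compound 4 (`O=C(/C=C/c1ccc([N+](=O)[O-])o1)c1ccc(Br)cc1`) has not yet been measured. It carries bromo in place of phenyl on an aromatic carbon, at a position para to a large group: bromo in place of phenyl on an aromatic carbon. Going by the values given here, no two measured compounds differ in only one place, so no measured step shows what such a change does in this assay. The expectation therefore rests on just a few values, and its range is kept wide. Compound 1 lies at the upper end of the numbers, while compound 3 at 13500 nM shows that lower numbers occur in the series. The expected change is a 2.5-fold lower number from compound 1 to compound 4 (0.40 log units; beyond the scatter), a moderate move towards less compound tolerated and probably beyond the scatter. For compound 4 the estimated value is 20000 nM, with an expected range from 7000 nM to 50000 nM.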

Compound 4, half-maximal cytotoxic concentration: 13400 nM
Beside the measured number, compound 4's estimate is 1.5-fold (0.17 log units) above it; the measured number falls inside the stated range.
By their numbers in this assay, from the lowest: compounds 4 and 3 (each within the scatter of the next); then compound 1.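

Going by these compounds alone, this is the first step that can be read in this assay, and it gives a 3.8-fold lower number from compound 1 to compound 4 (0.58 log units; beyond the scatter). It shows that this place on the core of compound 1, an aromatic carbon para to a large group, is not indifferent to what it carries: bromo in place of phenyl moves the number towards less compound tolerated, by a modest step beyond the scatter. The change takes away a whole six-membered aromatic ring of carbon only and leaves a single bromine in its place, so this one step cannot separate the loss of the ring from the arrival of the bromine.

On these data alone, whether a methyl, a methoxy, an amine or plain hydrogen at the same place would sit with compound 4 or with compound 1 stays open, as does whether bromo in place of phenyl would act in the same way on a different core. Compound 2 also carries phenyl, but it gives no exact number to set against the others, since its reading is a limit: the limit of > 50000 nM in this assay, at which 1 of the 4 values shown sits.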